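A few compounds are considered here, and "the series" means these few. Any claim that something is new, unique, unknown or untested is made for them only; others in the source may bear on it.

In an ADME assay on the whole organism (Mus musculus, strain C57BL6/N) for pharmacokinetics, read by LC-MS, with a stated time of 24 h, at a dose of 1 mg/kg by the intravenous route (a higher number here means faster removal of the compound, a lower number slower removal), compound 1 `CNc1cc(C)c(C(N)=O)cn1` gives 62.8 mL/min/kg and compound 2 `NC(=O)c1cnc2c(c1)CCN2` gives 64.2 mL/min/kg, while compound 3 `Cc1c(C(N)=O)cnc2c1CCN2` stands highest of the three at 182 mL/min/kg. Compound 4 `NC(=O)c1cnc2c(c1Cl)CCN2` has not yet been measured and differs from compound 3 by chloro in place of methyl on an aromatic carbon, with chloro in place of methyl on an aromatic carbon, opposite the ring nitrogen. Among the compounds with values here, no measured step involves chloro. The nearest evidence is a 2.8-fold higher number from compound 2 to compound 3 (0.45 log units; beyond the scatter), a modest change that adds methyl in place of hydrogen on the same aromatic carbon. Removing that methyl therefore points to a modest fall, though with real uncertainty, since chloro is not hydrogen. The expected change is a 1.7-fold lower number from compound 3 to compound 4 (0.24 log units; within the scatter). Compound 4 is estimated at 105 mL/min/kg, with an expected range of 55 mL/min/kg to 200 mL/min/kg.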

Compound 4, clearance: 179 mL/min/kg
The estimate for compound 4 lay 1.7-fold (0.23 log units) below the measured number, within the range that was stated.
By their numbers in this assay, from the lowest: compounds 1 and 2 (each within the scatter of the next); then compounds 4 and 3 (each within the scatter of the next).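

In this assay, chloro in place of methyl on this aromatic carbon, ortho to a carbamoyl group and opposite the ring nitrogen, gives a result within the scatter (a 1.0-fold lower number from compound 3 to compound 4 (0.01 log units; within the scatter)). Chloro in place of hydrogen gives a 2.8-fold higher number from compound 2 to compound 4 (0.45 log units; beyond the scatter), matching the step seen with methyl, so the higher number at this position is not tied to methyl alone. Nothing shown here explains why the two groups match.

Only hydrogen, methyl and chloro are compared at this position. From the compounds shown here alone, whether an amine, a methoxy group or a nitrile there would give a number like that of compound 2 or like those of compound 3 and compound 4 remains open.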